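Two Anilino Ethers Sitting at the Permeability Limit

This account rests on a few compounds, and the source may have more. Where it says the series, first, only, none or still open, it means among the compounds named here.

Compound 1, `CNC(=O)c1cc(Oc2ccc3nc(Nc4cccc(C(C)(C)C)c4)cnc3c2)ccn1`: < 1 10^-6 cm/s
Compound 2, `CNC(=O)c1cc(Oc2ccc3nc(Nc4cccc(Br)c4)ncc3c2)ccn1`: < 1 10^-6 cm/s

Both measured compounds share the same methylamide pyridyl ether and differ in the anilino substituent and in the position of a ring nitrogen in the core. In an ADME assay on Caco-2 cells (Homo sapiens) for permeability, in the apical to basolateral direction (a higher number here means that the compound crosses the layer faster, a lower number that the compound crosses the layer more slowly), compound 1 gives only a limit of the assay, not a number. In this assay compound 2 likewise gives only a limit of the assay. Compound 2 therefore stands at the floor of what this assay reports, and the limit of < 1 10^-6 cm/s in this assay, at which 2 of the 2 values shown sit, shows that nothing measured here has risen above it.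

Compound 3, `CNC(=O)c1cc(Oc2ccc3nc(Nc4ccc(C(C)C)cc4)ncc3c2)ccn1`, keeps the core of compound 2 and changes only the anilino group: 4-isopropylphenyl in place of 3-bromophenyl on a nitrogen on an aromatic ring. Going by the values given here, no measured pair differing in one place exists to size this step. Since compound 2 sits at a limit, a step in this assay can only be observed if compound 3 rises above that floor; given (the limit of < 1 10^-6 cm/s in this assay, at which 2 of the 2 values shown sit), this is expected to be modest at most, with the step from compound 2 to compound 3 estimated at a number no lower from compound 2 to compound 3 (the limit leaves the size open). Compound 3 is estimated at 1 10^-6 cm/s, within 0.3 10^-6 cm/s to 3 10^-6 cm/s.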

Compound 3, apparent permeability: < 1 10^-6 cm/s
Compound 3 ended at the assay's limit; the forecaster's own chance of this, stated with the estimate: 55%; the middle value sits exactly at the limit.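

In this assay compound 3 gives < 1 10^-6 cm/s, which is a limit of the assay and not a number. Going by these compounds alone, compound 2 also gives only a limit, so no step between compound 2 and compound 3 can be read. The compounds shown leave open whether these anilino groups or cores differ at all in permeability: the limit of < 1 10^-6 cm/s in this assay, at which 3 of the 3 values shown sit.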